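Aryl amide variation on a shared flavonol core

The source may hold more compounds than are shown below. What is called first, only, known or untested is meant among the compounds shown, and "the series" means these compounds.

The series keeps one core and varies the aryl amide attached to it. Compound 1 `COc1ccccc1C(=O)Nc1cccc(-c2oc3cc(-c4ccc(F)cc4)ccc3c(=O)c2O)c1` gives 9050 nM in a functional assay on HCC1937 cells (Homo sapiens) for antiproliferative activity, read by CCK-8 assay, with a stated time of 72 h; on this read-out higher numbers stand for weaker inhibition and lower numbers for stronger inhibition. Compound 2 `Cc1ccccc1C(=O)Nc1cccc(-c2oc3cc(-c4ccc(F)cc4)ccc3c(=O)c2O)c1` gives 9900 nM in this assay; the change is methyl in place of methoxy on an aromatic carbon, and the step is a 1.1-fold higher number from compound 1 to compound 2 (0.04 log units; within the scatter). Compound 3 `COc1cccc(C(=O)Nc2cccc(-c3oc4cc(-c5ccc(F)cc5)ccc4c(=O)c3O)c2)c1` gives 18900 nM in this assay; it differs from compound 1 by 3-methoxyphenyl in place of 2-methoxyphenyl on a carbonyl carbon, with the step of a 2.1-fold higher number from compound 1 to compound 3 (0.32 log units; beyond the scatter). Against compound 2 the step is a 1.9-fold higher number from compound 2 to compound 3 (0.28 log units; within the scatter).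

Compound 4 `Cc1cccc(C(=O)Nc2cccc(-c3oc4cc(-c5ccc(F)cc5)ccc4c(=O)c3O)c2)c1` has not yet been measured. It differs from compound 3 by methyl in place of methoxy on an aromatic carbon. This is the same kind of change as that from compound 1 to compound 2, but the place is not identical: there the group sits ortho to a large group, here meta to a large group. Because the step of a 1.1-fold higher number from compound 1 to compound 2 (0.04 log units; within the scatter) stayed within the scatter, a step of comparable size is expected for compound 3 to compound 4, namely a 1.1-fold higher number from compound 3 to compound 4 (0.02 log units; within the scatter). The estimate for compound 4 in this assay is 20000 nM, with an expected range from 10000 nM to 40000 nM.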

Compound 4, half-maximal inhibitory concentration: 8030 nM
Compound 4: the middle estimate sits 2.5-fold (0.40 log units) above what was measured; the whole stated range lies above it.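

In this assay, methyl in place of methoxy on the 3-methoxyphenyl amide gives a 2.4-fold lower number from compound 3 to compound 4 (0.37 log units; beyond the scatter), a step beyond the scatter, while the same change on the 2-methoxyphenyl amide stayed within it, yet the two steps cannot be told apart: the same change on two cores in this assay, a 1.1-fold higher number (0.04 log units; within the scatter) from compound 1 to compound 2 and a 2.4-fold lower number (0.37 log units; beyond the scatter) from compound 3 to compound 4, 2.6-fold (0.41 log units) apart, within the scatter of two such steps

The change therefore cannot be said to carry over differently between these two amides, but equally it is not shown to carry over unchanged, since each case rests on a single pair. The remaining steps, a 1.2-fold lower number from compound 2 to compound 4 (0.09 log units; within the scatter) and a 1.1-fold lower number from compound 1 to compound 4 (0.05 log units; within the scatter), both lie within the scatter, so compound 4 stands level with compound 1 and compound 2, and of the four compounds only compound 3 stands apart from any other, with its gap to compound 2 still within the scatter.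

Still open, going by these compounds, is whether an amine, a carboxylic acid or a chlorine in place of the methyl or methoxy on this phenyl would move the number beyond the scatter. Also open, on these data alone, is whether the methoxy to methyl step holds on a core carrying something other than the 4-fluorophenyl group.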